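Isopropylcarbonyl to 1-methylpiperidin-3-yl on the shared core

A few compounds are considered here, and "the series" means these few. Any claim that something is new, unique, unknown or untested is made for them only; others in the source may bear on it.

Results in a functional assay on KARPAS-299 cells (Homo sapiens) for inhibition, read by CellTiter-Glo, with a stated time of 96 h (on this read-out lower numbers stand for stronger inhibition and higher numbers for weaker inhibition), so far:
compound 1 `Cc1cc(Nc2ncc(Cl)c(Nc3cn(C)nc3S(=O)(=O)C(C)C)n2)c(OC2CC2)cc1C(=O)C(C)C` gives "not determined" (no result reported) as its result
compound 2 `Cc1cc(Nc2ncc(Cl)c(Nc3cn(C)nc3S(=O)(=O)C(C)C)n2)c(C(F)(F)F)cc1C1CCN(C)CC1` gives 74 nM as its result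
compound 3 `Cc1cc(Nc2ncc(Cl)c(Nc3cn(C)nc3S(=O)(=O)C(C)C)n2)c(OC(C)C)cc1C1CNC1` gives 60 nM as its result

Compound 1 has no number in this assay to serve as a starting point. The next structure is compound 4 `Cc1cc(Nc2ncc(Cl)c(Nc3cn(C)nc3S(=O)(=O)C(C)C)n2)c(OC2CC2)cc1C1CCCN(C)C1`, still unmeasured. The change is 1-methylpiperidin-3-yl in place of isopropylcarbonyl on an aromatic carbon, in words 1-methylpiperidin-3-yl in place of isopropylcarbonyl on an aromatic carbon. No size or direction of step can be stated from compound 1. Compound 2 at 74 nM and compound 3 at 60 nM lie within scatter of each other, and each carries a non-aromatic nitrogen ring at that place, so a similar level is expected. For compound 4 the estimate is 55 nM, with 18 nM to 170 nM as the expected span.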

Compound 4, half-maximal inhibitory concentration: 3 nM
Beside the measured number, compound 4's estimate is 18-fold (1.26 log units) above it; measured number outside the range, below it.
By their numbers in this assay, from the lowest: compound 4; then compounds 3 and 2 (each within the scatter of the next).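

Within the data shown here, compound 1 stands at "not determined" (no result reported) in this assay and so no step to compound 4 can be read. The compounds shown leave open what the change from isopropylcarbonyl to 1-methylpiperidin-3-yl alone does on the shared core, as compound 4 differs from compounds 2 and 3 in more than one place. No measurement on hand bears on the result for compound 4.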